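The source may hold more compounds than are shown below. What is called first, only, known or untested is meant among the compounds shown, and "the series" means these compounds.

Measured so far:
- Compound 1, `CCC(CO)Nc1nc(NCc2ccccc2)c2nc(Cl)n(C(C)C)c2n1`: 91000 nM
- Compound 2, `CCC(CO)Nc1nc(NCc2ccccc2)c2nc([N+](=O)[O-])n(C(C)C)c2n1`: 117000 nM

In a functional assay on K562 cells (Homo sapiens) for cytotoxicity (on this read-out higher numbers stand for weaker inhibition and lower numbers for stronger inhibition), compound 1 stands at the lowest of the two numbers; its nearest neighbour is compound 2, and the step of a 1.3-fold higher number from compound 1 to compound 2 (0.11 log units; within the scatter) lies within the scatter, so the two values cannot be told apart. Compound 3, `CCC(CO)Nc1nc(NCc2ccccc2)c2nc(NCCCO)n(C(C)C)c2n1`, has not been measured. It differs from compound 1 in one place: (3-hydroxypropyl)amino in place of chloro on an aromatic carbon. For the measured compounds named here, the one measured step, from compound 1 to compound 2, concerns a different replacement at the same aromatic carbon and therefore bears only loosely on the change at hand; it shows that one exchange there left this assay unmoved beyond the scatter. With nothing else to go on, the step of a 1.3-fold higher number from compound 1 to compound 3 (0.12 log units; within the scatter) is expected to stay within the scatter as well. Compound 3 is estimated at 120000 nM, with a range from 40000 nM to 350000 nM.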

Compound 3, half-maximal inhibitory concentration: 30000 nM
Compound 3: middle estimate off by 4.0-fold (0.60 log units), on the high side, outside the stated range (below it).
By their numbers in this assay, from the lowest: compound 3; then compounds 1 and 2 (each within the scatter of the next).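

In this assay the aromatic carbon between two ring nitrogen atoms proves able to shift the number: (3-hydroxypropyl)amino gives a 3.0-fold lower number from compound 1 to compound 3 (0.48 log units; beyond the scatter) and a 3.9-fold lower number from compound 2 to compound 3 (0.59 log units; beyond the scatter) in the same direction. For the compounds shown here, the exchange of chloro for nitro had stayed within the scatter, so this chain is the first change at the position to go beyond it, although both steps remain modest. Nothing available explains why this group lowers the number.

The compounds shown do not separate the part played by the amino nitrogen from that of the terminal hydroxyl or of the chain as a whole; a plain amino group, a propylamino group without the hydroxyl or a longer hydroxyalkylamino chain would bear on this. Going by these compounds, whether the step would hold with other groups elsewhere on the shared core also stays open.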